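The source may hold more compounds than are shown below. What is called first, only, known or untested is meant among the compounds shown, and "the series" means these compounds.

Measured compounds in this assay:
- compound 3 `CCn1cc(-c2cc(Oc3ccc(-c4cnc(NC(C)C)[nH]c4=O)nc3C)ccn2)cn1`: 13 nM
- compound 1 `Cc1nc(-c2cnc(NC3CC3)[nH]c2=O)ccc1Oc1ccnc(-c2cnn(C)c2)c1`: 55 nM
- compound 2 `CCNc1ncc(-c2ccc(Oc3ccnc(-c4ccc(C)nc4)c3)c(C)n2)c(=O)[nH]1`: 1200 nM

In a functional assay on NFS-60 cells (Mus musculus) for antiproliferative activity, read by resazurin assay, with a stated time of 72 h (a lower number here means a stronger inhibitor, a higher number a weaker inhibitor), compound 3 gives the lowest of the three numbers. Its gap to compound 1 and its gap to compound 2 both lie beyond the scatter, so compound 3 is the strongest inhibitor among the measured set, and compound 2 is the weakest.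

Compound 4 `CC(=O)Nc1cc(Oc2ccc(-c3cnc(NC(C)C)[nH]c3=O)nc2C)ccn1` has not yet been measured in this assay. The change from compound 3 to compound 4 is acetamido in place of 1-ethyl-1H-pyrazol-4-yl on an aromatic carbon. For the measured compounds named here, no pair of measured compounds differs in exactly this way, so the size of the step has no direct precedent here; the shared core and the aryl ether linkage are unchanged.

The step is expected to weaken the compound, by an amount beyond the scatter: the expected step is a 7.7-fold higher number from compound 3 to compound 4 (0.89 log units; beyond the scatter). Compound 4 is estimated at 100 nM, with a range from 25 nM to 400 nM.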

Compound 4, half-maximal inhibitory concentration: 193 nM
Beside the measured number, compound 4's estimate is 1.9-fold (0.29 log units) below it, within the range that was stated.
By their numbers in this assay, from the lowest: compound 3; then compound 1; then compound 4; then compound 2.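

In this assay, the aromatic carbon next to the ring nitrogen now has its first direct reading: acetamido in place of 1-ethyl-1H-pyrazol-4-yl gives a large loss of potency (a 15-fold higher number from compound 3 to compound 4 (1.17 log units; beyond the scatter)). This single step removes a five-membered aromatic ring and adds a hydrogen-bond donor on a group with fewer heavy atoms, so the contribution of each of these differences cannot be separated. No measurement shown accounts for the size of this step.

Still open, on these data alone, is whether a small non-ring group can do better at this carbon than acetamido, for example a primary amine or a plain methoxy group. Also open, as far as these compounds go, is whether the step keeps its size when the isopropylamino group on the shared core is replaced by cyclopropylamino or ethylamino.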